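Allyl in Place of Phenyl: Expected Paw Edema Inhibition

The source may hold more compounds than are shown below. What is called first, only, known or untested is meant among the compounds shown, and "the series" means these compounds.

Compound 1 `COc1ccc(-c2nnc(SCC(=O)Nc3ccc(/C(C)=N/O)cc3)n2-c2ccccc2)cc1OC` gives 76% in a functional assay on the whole organism (strain albino) for inhibition, with Rattus norvegicus as the target, read by paw edema, with stated times of 30 min and 5 h, at a dose of 0.28 mmol/kg by the oral route; on this read-out lower numbers stand for less inhibition and higher numbers for more inhibition at the one dose given (going by the name of the read-out). Compound 2 `C=CCn1c(SCC(=O)Nc2ccc(/C(C)=N/O)cc2)nnc1-c1ccc(OC)c(OC)c1` gives 79% in this assay. The change between the two is allyl in place of phenyl on an aromatic nitrogen, and it made a step of a number 3 percentage points higher from compound 1 to compound 2 (within the scatter). Compound 3 `COc1cc(-c2nnc(SCC(=O)Nc3ccc(C(C)=O)cc3)n2-c2ccccc2)cc(OC)c1OC` gives 63% in this assay, the lowest of the three numbers; how its core differs from the core of compound 1 is not broken down here.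

Compound 4 `C=CCn1c(SCC(=O)Nc2ccc(C(C)=O)cc2)nnc1-c1cc(OC)c(OC)c(OC)c1` is not yet measured. It differs from compound 3 by allyl in place of phenyl on an aromatic nitrogen. Within the data shown here, this is the same kind of change as the one from compound 1 to compound 2, but not the same: around the place, the ring atom bears a 3,4,5-trimethoxyphenyl group in compound 3, while in compound 1 it bears a 3,4-dimethoxyphenyl group. Because the earlier step of a number 3 percentage points higher from compound 1 to compound 2 (within the scatter) stayed within the scatter, a step of about a number 3 percentage points higher from compound 3 to compound 4 (within the scatter) is expected here as well, starting from the value of compound 3. Compound 4 is therefore estimated at 66%, with a plausible range from 54% to 78%.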

Compound 4, a percentage reported as inhibition, in the whole organism at one dose (the size of the read-out at that dose, not a potency): 64%
Estimate against measurement, compound 4: 2 percentage points above; the range from low to high includes it.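

In this assay, allyl in place of phenyl on an aromatic nitrogen made a step of a number 1 percentage points higher from compound 3 to compound 4 (within the scatter). Set beside the earlier step, the change carries across the two cores with no difference that can be told apart: the same change on two cores in this assay, a number 3 percentage points higher (within the scatter) from compound 1 to compound 2 and a number 1 percentage points higher (within the scatter) from compound 3 to compound 4, 2 percentage points apart, within the scatter of two such steps. This shows that on both cores the swap from the ring of phenyl to the open chain of allyl left the inhibition within the scatter at the one dose given, but it does not show that the same would hold on any other core, nor does it say anything about potency.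

The compounds shown leave open what other groups on that aromatic nitrogen would do, for instance a methyl, a benzyl or a longer chain such as butyl in place of allyl. They also leave open whether an amine or a carboxylic acid carried on a chain at that place would move the inhibition beyond the scatter.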